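Compound 3 to Compound 4: Sulfonyl in Place of Sulfanyl

The source may hold more compounds than are shown below. What is called first, only, known or untested is meant among the compounds shown, and "the series" means these compounds.

Compound 3 `O=C(/C(=C\c1c(O)cc(O)cc1O)SCc1ccc(Cl)c(Cl)c1)c1ccc(Cl)cc1` gives 25000 nM in a functional assay on DU-145 cells (Homo sapiens) for inhibition, read by trypan blue exclusion, with a stated time of 96 h; on this read-out higher numbers stand for weaker inhibition of growth and lower numbers for stronger inhibition of growth. Among the three measured numbers it stands second highest: compound 2 `Cc1ccsc1/C=C(/SCc1ccc(Cl)c(Cl)c1)C(=O)c1ccc(Cl)cc1` gives 50000 nM, and a 2.0-fold lower number from compound 2 to compound 3 (0.30 log units; within the scatter) lies within the scatter, while compound 1 `COc1ccccc1/C=C(/SCc1ccc(Cl)c(Cl)c1)C(=O)c1ccc(Cl)cc1` gives 10000 nM, and a 2.5-fold higher number from compound 1 to compound 3 (0.40 log units; beyond the scatter) lies beyond it. Compound 4 `Cc1ccc(S(=O)(=O)/C(=C/c2c(O)cc(O)cc2O)C(=O)c2ccc(Cl)cc2)cc1` differs from compound 3 in one place: (4-methylphenyl)sulfonyl in place of (3,4-dichlorobenzyl)sulfanyl on a double-bonded chain carbon bound to a carbonyl carbon and a double-bonded chain carbon. Every measured step, a 5.0-fold higher number from compound 1 to compound 2 (0.70 log units; beyond the scatter) as well as the two just named, alters the group on a double-bonded chain carbon bound to a double-bonded chain carbon and leaves the (3,4-dichlorobenzyl)sulfanyl untouched, so none of them bears on this change. Compound 4 is therefore expected to show no change at the digits printed from compound 3 to compound 4 (within the scatter), no step beyond the scatter, with a wide range. Compound 4 is estimated at 25000 nM, between 8000 nM and 80000 nM.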

Compound 4, concentration for 50% growth inhibition: > 100000 nM
Compound 4 gave a limit, no number (the forecaster's own chance of this, stated with the estimate: 20%); at least 4.0-fold (0.60 log units) between middle value and limit.
By their numbers in this assay, from the lowest: compound 1; then compounds 3 and 2 (each within the scatter of the next). At a limit, above all of these: compound 4.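

In this assay, for the compounds shown here, the earlier steps all left the (3,4-dichlorobenzyl)sulfanyl untouched, so this is the first sign that the read-out responds to the group on a double-bonded chain carbon bound to a carbonyl carbon and a double-bonded chain carbon. Putting (4-methylphenyl)sulfonyl in its place gives an at least 4.0-fold higher number from compound 3 to compound 4 (0.60 log units; beyond the scatter), a loss of growth inhibition beyond the scatter. The value of compound 4 is a limit and not a number: the limit of > 100000 nM in this assay, at which 1 of the 4 values shown sits.

From the compounds shown here alone, the sulfur's state and the aromatic group change together here, so their separate contributions remain open. Going by these compounds, how an amine or a carboxylic acid at this place would read also remains open.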